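A Bromo Group on the Chain of Compound 3

A few compounds are considered here, and "the series" means these few. Any claim that something is new, unique, unknown or untested is made for them only; others in the source may bear on it.

In a functional assay on SF-295 cells (Homo sapiens) for cytotoxicity, read by MTT assay, with a stated time of 72 h (a higher number here means a weaker inhibitor, a lower number a stronger inhibitor), compound 1 `CCCCCCCCCCCCCC(O)C1OC(=O)c2c(OC)cccc21` is reported only as a limit, > 25 ug/mL. Compound 2 `CCCCCCCCCCCCCC(=O)C1OC(=O)c2c(OC)cccc21` gives a number, 10.1 ug/mL. Compound 3 `CCCCCCCCCCCCCCCc1cccc(OC)c1C(=O)OC` is also reported only as a limit, > 25 ug/mL. Compound 4 `CCCCCCCCCCCCCCC(Br)c1cccc(OC)c1C(=O)OC` carries bromo in place of hydrogen on a saturated chain carbon bound to an aromatic carbon and a saturated chain carbon. Among the compounds with values here, no measured pair shows this change, so any expectation for this assay is loose. A modest shift toward stronger inhibition is expected, and a result at the limit would be no surprise. The expected step is an at least 1.3-fold lower number from compound 3 to compound 4 (0.14 log units; that floor lies within the scatter). Compound 4 is estimated at 18 ug/mL, with an expected range from 7 ug/mL to 30 ug/mL.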

Compound 4, half-maximal inhibitory concentration: > 25 ug/mL
Compound 4: a limit, no number; the forecaster's own chance of this, stated with the estimate: 50%; middle value at least 1.3-fold (0.14 log units) away from the limit.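

Compound 3 and compound 4 are both reported only as limits in this assay, so no step between them can be read: the limit of > 25 ug/mL in this assay, at which 3 of the 4 values shown sit.

Going by these compounds, whether the bromo group changes the result in either direction remains open.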